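Swapping methyl for phenyl on two related cores

A few compounds are considered here, and "the series" means these few. Any claim that something is new, unique, unknown or untested is made for them only; others in the source may bear on it.

Compound 1 `COc1cc(/C=C\Cc2cc(O)c3cc(C)sc3c2)cc(OC)c1OC`: 23 nM
Compound 2 `COc1cc(/C=C\Cc2cc(O)c3cc(C)oc3c2)cc(OC)c1OC`: 93 nM
Compound 3 `COc1cc(/C=C\Cc2cc(O)c3cc(-c4ccccc4)oc3c2)cc(OC)c1OC`: > 2000 nM

All three measured compounds were tested in a functional assay on BMEC cells (Bos taurus) for antiproliferative activity; a lower number here means a stronger inhibitor, a higher number a weaker inhibitor. Compound 1 gives 23 nM, the lowest of the two plain numbers, and compound 2 gives 93 nM, a higher number by a margin beyond the usual scatter. The difference between the two cores of compound 1 and compound 2 is not broken down here.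

Compound 3 differs from compound 2 in one place: phenyl in place of methyl on an aromatic carbon. The effect is large: an at least 21-fold higher number from compound 2 to compound 3 (1.33 log units; beyond the scatter). The value for compound 3 is a limit of the assay, not a number: it sits at the limit of > 2000 nM in this assay, at which 1 of the 3 values shown sits.

Compound 4 `COc1cc(/C=C\Cc2cc(O)c3cc(-c4ccccc4)sc3c2)cc(OC)c1OC` is not yet measured. It differs from compound 1 in a single place: phenyl in place of methyl on an aromatic carbon. Among the measured compounds shown here, this is the same kind of change as the one from compound 2 to compound 3, though not the same: in compound 4 the phenyl enters next to the ring sulfur of a five-membered aromatic ring with one sulfur, whereas in compound 3 it enters next to the ring oxygen of a five-membered aromatic ring with one oxygen. Since the change on the oxygen core cost compound 3 so much in this assay, a step of similar size is expected from compound 1 to compound 4, a 30-fold higher number from compound 1 to compound 4 (1.48 log units; beyond the scatter), resting on an at least 21-fold higher number from compound 2 to compound 3 (1.33 log units; beyond the scatter). The estimate for compound 4 in this assay is therefore 700 nM, between 200 nM and 2000 nM, with a real chance that only a limit is reported.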

Compound 4, half-maximal inhibitory concentration: 23000 nM
The estimate for compound 4 lay 33-fold (1.52 log units) below the measured number; measured number outside the range, above it.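

In this assay, putting phenyl in place of methyl on an aromatic carbon, next to the ring sulfur, gives a 1000-fold higher number from compound 1 to compound 4 (3.00 log units; beyond the scatter). Set beside the same change on the core of compound 2, the direction carries over, with the number rising beyond the scatter on both cores: the same change on two cores in this assay, an at least 21-fold higher number (1.33 log units; beyond the scatter) from compound 2 to compound 3 and a 1000-fold higher number (3.00 log units; beyond the scatter) from compound 1 to compound 4; the limit leaves it open whether they differ Compound 3 gives only a limit and not a number, > 2000 nM, so the comparison shows that the change is costly on both cores but does not show whether the cost is larger on one of them, and two pairs of compounds establish no rule for other cores in this series.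

The compounds shown leave open how the number would move with other groups on that same carbon, for example ethyl, an isopropyl group, a chain carrying an amine, or a carboxylic acid, so it cannot be said where between methyl and phenyl the loss sets in. They also leave open whether a phenyl ring bearing a methoxy group or a fluorine would behave like the plain phenyl of compound 3 and compound 4.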